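Fluoro for Bromo on a Shared Core at the Limit

A few compounds are considered here, and "the series" means these few. Any claim that something is new, unique, unknown or untested is made for them only; others in the source may bear on it.

Compound 2 `O=C(CNc1ccc(Br)cc1)N[C@H]1CCOC1=O` is one of two analogues tested in a functional assay on DU-145 cells (Homo sapiens) for antiproliferative activity, read by MTT assay, with a stated time of 72 h; a lower number here means a stronger inhibitor, a higher number a weaker inhibitor. In this assay compound 2 gives > 64000 nM, which is a limit of the assay rather than a measured number. Compound 1 `CC(C)c1ccc(NCC(=O)N[C@H]2CCOC2=O)cc1` likewise gives > 64000 nM, again only a limit. The step that the two limits leave unreadable from compound 1 to compound 2 therefore cannot be sized, as the limit of > 64000 nM in this assay, at which 2 of the 2 values shown sit, shows. Compound 3 `O=C(CNc1ccc(F)cc1)N[C@H]1CCOC1=O` differs from compound 2 by fluoro in place of bromo on an aromatic carbon. No readable step exists to guide this change, so compound 3 is expected to remain at the limit, with an estimated value of 80000 nM (range 30000 nM to 200000 nM), meaning an expected step that the limit leaves unreadable from compound 2 to compound 3 of no readable size.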

Compound 3, half-maximal inhibitory concentration: > 64000 nM
Compound 3 ended at the assay's limit (the forecaster's own chance of this, stated with the estimate: 85%); the middle value does not contradict the limit.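

No step among compound 1, compound 2 and compound 3 can be read in this assay, because all three stop at a limit of the assay rather than a measured number: the limit of > 64000 nM in this assay, at which 3 of the 3 values shown sit.

The compounds shown leave open whether any group at this aromatic carbon of the shared core gives a readable value.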